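Swapping methyl for cyclopropyl on the pyrazole nitrogen

The compounds below may be only part of what the source reports. "The series", "measured", "known", "first", "only" and "open" are said of these compounds alone.

Compound 1 `Cc1ccc(C(=O)Nc2cccc(C(F)(F)F)c2)cc1-c1ccc2c(-c3ccc(N4CCN(C)CC4)cc3)n[nH]c2c1`: 8.8 nM
Compound 2 `Cc1ccc(C(=O)Nc2cccc(C(F)(F)F)c2)cc1-c1ccc2c(-c3ccc(CN4CCN(C)CC4)cc3)n[nH]c2c1`: 6.2 nM
Compound 3 `Cc1ccc(C(=O)Nc2cccc(C(F)(F)F)c2)cc1-c1ccc2c(-c3cnn(C)c3)n[nH]c2c1`: 4.4 nM

All three were tested in an assay on isolated protein for inhibition of Discoidin domain-containing receptor 2 (Homo sapiens), read by ELISA, with a stated time of 60 min; on this read-out higher numbers stand for weaker inhibition and lower numbers for stronger inhibition. Compound 3 gives the lowest number of the three, yet its gap to compound 2 and to compound 1 each lies within the scatter, so the three cannot be ranked. Among the measured compounds shown here, the only single-point step measured, a 1.4-fold lower number from compound 1 to compound 2 (0.15 log units; within the scatter), concerns the other end of the molecule and does not touch the group changed here. Compound 4 `Cc1ccc(C(=O)Nc2cccc(C(F)(F)F)c2)cc1-c1ccc2c(-c3cnn(C4CC4)c3)n[nH]c2c1` carries cyclopropyl in place of methyl on an aromatic nitrogen. For the measured compounds named here, no measured step bears on this change, so the expectation is a step no larger than the scatter, in no particular direction: the estimated step is a 1.0-fold higher number from compound 3 to compound 4 (0.01 log units; within the scatter). Compound 4 is thus expected to give about 4.5 nM, within the range 2 nM to 11 nM.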

Compound 4, half-maximal inhibitory concentration: 3.2 nM
The estimate for compound 4 lay 1.4-fold (0.15 log units) above the measured number, and the stated range covers the measured number.
By their numbers in this assay, from the lowest: compounds 4, 3, 2 and 1 (each within the scatter of the next, the first and the last beyond it).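

Until now only methyl had been seen on this aromatic nitrogen of the pyrazole. In this assay, cyclopropyl in its place gives a 1.4-fold lower number from compound 3 to compound 4 (0.14 log units; within the scatter), so a three-membered carbon ring sits at this position with no step beyond the scatter. Nothing measured here speaks to why the number stays in this range.

Still open, going by these compounds, is how this nitrogen would respond to a longer chain, such as butyl, or to a chain ending in an amine or a carboxylic acid. Also open, on these data alone, is whether cyclopropyl would give a similar step with the methylpiperazine-bearing groups of compound 1 and compound 2 in place of the pyrazole.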